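A few compounds are considered here, and "the series" means these few. Any claim that something is new, unique, unknown or untested is made for them only; others in the source may bear on it.

Working notes on the series, read in a functional assay on MCF7 cells (Homo sapiens) for antiproliferative activity, read by MTT assay; on this read-out higher numbers stand for weaker inhibition and lower numbers for stronger inhibition. Compound 1 `CC/C=C\C/C=C\C/C=C\CCCCCCCc1cc(=O)c2c(O)cc(OCOC)cc2o1` gives 17500 nM. Compound 2 `CC/C=C\C/C=C\C/C=C\CCCCCCCc1cc(=O)c2c(O)c(C)c(O)cc2o1` gives 17500 nM, the same reading as compound 1. Compound 3 `CC/C=C\C/C=C\C/C=C\CCCCCCCc1cc(=O)c2c(O)c(C)c(OCOC)c(C)c2o1` gives > 84100 nM, which is a limit of this assay and not a number.

Compound 4 `CC/C=C\C/C=C\C/C=C\CCCCCCCc1cc(=O)c2c(O)c(C)c(OCOC)cc2o1` differs from compound 3 at one place: hydrogen in place of methyl on an aromatic carbon. Going by the values given here, the series holds no measured step for a change at one place, so the expectation rests on indirect comparison. Compound 1 at 17500 nM also has hydrogen on that carbon and keeps the methoxymethoxy group. Compound 2 at 17500 nM also has hydrogen there and keeps the neighbouring methyl group of compound 3, while compound 4 carries both features. A moderate step toward stronger inhibition is therefore expected in this assay. The expected change is an at least 2.8-fold lower number from compound 3 to compound 4 (0.44 log units; beyond the scatter). Compound 4 is estimated at 30000 nM, with an expected range of 12000 nM to 80000 nM.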

Compound 4, half-maximal inhibitory concentration: 17500 nM
For compound 4 the middle estimate is 1.7-fold (0.23 log units) above the measured one; the range from low to high includes it.
By their numbers in this assay, from the lowest: compounds 1, 2 and 4 (each within the scatter of the next). At a limit, above all of these: compound 3.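

In this assay, going by these compounds alone, hydrogen in place of methyl on the aromatic carbon ortho to a methoxymethoxy group gives the first measured step at this position, an at least 4.8-fold lower number from compound 3 to compound 4 (0.68 log units; beyond the scatter), and its size is only a bound since compound 3 stands at a limit and not a number: the limit of > 84100 nM in this assay, at which 1 of the 4 values shown sits. The two other single changes leading to compound 4 behave differently: methoxymethyl in place of hydrogen on the oxygen gives no change at the digits printed from compound 2 to compound 4 (within the scatter), and methyl in place of hydrogen on an aromatic carbon gives no change at the digits printed from compound 1 to compound 4 (within the scatter). Among these four compounds, only the methyl group para to a hydroxy group separates a reading from the limit.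

On these data alone, the true number for compound 3 stays open. So does whether an ethyl group, a chlorine atom or an amine on that same carbon would behave like methyl or like hydrogen.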